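Replacing a methoxyphenyl by a difluorophenyl on the ketone arm

The source may report more compounds than this note shows. Statements on the series, on what has been measured and on what is new or still open speak of the compounds shown alone.

In a functional assay on NCI-H522 cells (Homo sapiens) for cytotoxicity, read by sulforhodamine B assay, with a stated time of 48 h, tested at 10 uM (a higher number here means a weaker effect of the compound at the concentration tested, a lower number a stronger effect), the three measured compounds gave these results:
compound 1 `COc1cc(-c2cc(/C=C/C(=O)c3ccc(N)cc3)[nH]n2)cc(OC)c1OC`: -51%
compound 2 `COc1ccc(C(=O)/C=C/c2cc(-c3cc(OC)c(OC)c(OC)c3)n[nH]2)cc1OC`: -95%
compound 3 `COc1ccc(C(=O)/C=C/c2cc(-c3cc(OC)c(OC)c(OC)c3)n[nH]2)cc1`: -73%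

Compound 3 stands second highest of the three numbers, with compound 1 above it and compound 2 below it, both beyond the scatter. Compound 4 `COc1cc(-c2cc(/C=C/C(=O)c3ccc(F)c(F)c3)[nH]n2)cc(OC)c1OC` differs from compound 3 in one place: 3,4-difluorophenyl in place of 4-methoxyphenyl on a carbonyl carbon. Among the measured compounds shown here, no measured step brings in a fluorine-bearing ring, so the guidance is indirect. The steps of a number 22 percentage points higher from compound 2 to compound 3 (beyond the scatter), a number 22 percentage points lower from compound 1 to compound 3 (beyond the scatter) and a number 44 percentage points lower from compound 1 to compound 2 (beyond the scatter) show that every change made so far to this ring moved the number beyond the scatter, the removal of a methoxy making the effect weaker. A modest weakening step is therefore expected, a number 15 percentage points higher from compound 3 to compound 4 (beyond the scatter). Compound 4 is estimated at -58%, with a range from -90% to -25%.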

Compound 4, a percentage reported as activity, at one concentration (the size of the read-out at that concentration, not a potency): -38%
For compound 4 the middle estimate is 20 percentage points below the measured one; low and high end bracket the measured number.
By their numbers in this assay, from the lowest: compound 2; then compound 3; then compound 1; then compound 4.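

In this assay the steps of a number 35 percentage points higher from compound 3 to compound 4 (beyond the scatter) and a number 57 percentage points higher from compound 2 to compound 4 (beyond the scatter) and a number 13 percentage points higher from compound 1 to compound 4 (beyond the scatter) make 3,4-difluorophenyl the weakest of the four rings on this carbonyl carbon. A fluorine-bearing ring therefore does not keep the effect of the two methoxy-bearing rings, and it also falls behind 4-aminophenyl. Nothing measured here explains this loss of effect. On these data alone, it remains open whether a 4-fluorophenyl ring, with a single fluorine, would lose as much, and how a 4-chlorophenyl or 4-hydroxyphenyl ring would compare at this place.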